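Replacing an Aryl on the Ring Nitrogen with a Urea

A few compounds are considered here, and "the series" means these few. Any claim that something is new, unique, unknown or untested is made for them only; others in the source may bear on it.

Of the compounds shown here, three from this series have been measured in a functional assay on cells (T-cell, Homo sapiens) for inhibition; a lower number here means a stronger inhibitor, a higher number a weaker inhibitor. Compound 1, `CCOc1nc(N)nc2ncc(-c3ccc(Cl)c(Cl)c3)nc12`, sits at the limit of the assay in this assay, where compound 1 gives > 10000 nM, a limit rather than a number (the limit of > 10000 nM in this assay, at which 1 of the 3 values shown sits). Compound 3, `CCOc1nc(N)nc2ncc(-c3ccc(CC)cc3)nc12`, gives 8200 nM in this assay. Compound 2, `COc1ccc(-c2cnc3nc(N)nc(N4CCN(c5ccc(C)cc5)CC4)c3n2)cc1OC`, gives 300 nM in this assay, the lowest of the two numbers, and its gap to compound 3 lies beyond the usual scatter.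

Compound 4, `COc1ccc(-c2cnc3nc(N)nc(N4CCN(C(=O)NCc5ccc(F)cc5)CC4)c3n2)cc1OC`, has not yet been measured. It differs from compound 2 in one place, ((4-fluorobenzyl)carbamoyl in place of 4-methylphenyl on an amine nitrogen in a ring). The shared core of compound 2 and compound 4 is unchanged, and the change sits only on the amine nitrogen in a ring of the six-membered non-aromatic ring with two nitrogens. Among the compounds with values here, no measured pair in this set shows a step of this kind, so nothing here tells how the (4-fluorobenzyl)carbamoyl group compares with 4-methylphenyl.

Compound 4 is therefore expected to land near compound 2, with a small step toward a higher number, a 2.0-fold higher number from compound 2 to compound 4 (0.30 log units; within the scatter), that may fall within the scatter. The estimate for compound 4 in this assay is 600 nM, with a range from 150 nM to 3000 nM.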

Compound 4, half-maximal inhibitory concentration: 37 nM
Beside the measured number, compound 4's estimate is 16-fold (1.21 log units) above it; measured number below the stated range.
By their numbers in this assay, from the lowest: compound 4; then compound 2; then compound 3. At a limit, above all of these: compound 1.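

On the amine nitrogen in a ring of the six-membered non-aromatic ring with 2 nitrogen, putting (4-fluorobenzyl)carbamoyl in place of 4-methylphenyl gives an 8.1-fold lower number from compound 2 to compound 4 (0.91 log units; beyond the scatter) in this assay and is the only single-place step in the compounds shown. This position therefore responds to a change in the group it carries, and in compound 4 an aromatic ring attached directly to that nitrogen is not needed for inhibition: a carbonyl now stands on the nitrogen, with an amide hydrogen and a benzyl group further out. Nothing measured here accounts for the step, and which part of the new group carries it stays unresolved.

From the compounds shown here alone, the carbonyl, the amide hydrogen, the benzyl carbon and the fluorine all enter together, so it remains open whether a plain amide or a carbamate on the same nitrogen would match compound 4. Also open, going by these compounds, are how an unsubstituted benzyl group, a chlorine in place of the fluorine, or a longer chain between the amide nitrogen and the aromatic ring would compare.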